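The source may hold more compounds than are shown below. What is called first, only, known or untested is meant among the compounds shown, and "the series" means these compounds.

Working notes on the series. Of the compounds shown here, two sharing one core have been measured. Compound 1 `C/C(=N\O)c1ccc(NC(=O)Cn2nc(-c3ccc(Cl)cc3)nc2N)cc1` carries a chlorophenyl on the core; compound 2 `C/C(=N/O)c1ccc(NC(=O)Cn2nc(-c3ccccc3)nc2N)cc1` carries an unsubstituted phenyl there. In a functional assay on OVCAR-8 cells (Homo sapiens) for inhibition, read by sulforhodamine B assay, with a stated time of 48 h, tested at 10 uM (a higher number here means more inhibition of growth at the concentration tested, a lower number less inhibition of growth), compound 1 gives 18%. In this assay compound 2 gives 15.3%, and the gap between compound 2 and compound 1 is within the usual scatter, so neither number can be set apart from the other; both show only modest inhibition of growth at the concentration tested.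

Compound 3 `CC(=O)c1ccc(NC(=O)Cn2nc(-c3ccc(Cl)cc3)nc2N)cc1` has not been measured yet. Relative to compound 1 its difference is a group of 3 heavy atoms (2 carbon, 1 oxygen; no ring) in place of a group of 4 heavy atoms (2 carbon, 1 nitrogen, 1 oxygen; no ring), on an aromatic carbon. For the measured compounds named here, no measured step of this kind exists; the only measured pair differs elsewhere on the core and shows no change beyond the scatter.

With nothing measured about this change, the step from compound 1 to compound 3 is expected to be small, within or near the scatter, with no clear direction: the expected step is a number 3 percentage points lower from compound 1 to compound 3 (within the scatter). Compound 3 is accordingly estimated to give 15% in this assay, in an expected range from 4% to 28%.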

Compound 3, percent growth inhibition at one concentration: 15.4%
The estimate for compound 3 lay 0.4 percentage points below the measured number, within the range that was stated.
By their numbers in this assay, from the lowest: compounds 2, 3 and 1 (each within the scatter of the next).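

In this assay, exchanging the group of 4 heavy atoms for acetyl on the aromatic carbon para to a large group gives a number 2.6 percentage points lower from compound 1 to compound 3 (within the scatter), the only step at this position among the compounds shown. Acetyl carries 0 hydrogen-bond donors where the group it replaces carries 1, and it has one hydrogen-bond acceptor fewer, yet the number does not move beyond the scatter, so this single pair shows no dependence of growth inhibition on those counts at this position. Nothing at hand explains this result.

As far as these compounds go, whether a primary amine, a carboxylic acid or a longer chain in place of acetyl on this aromatic carbon would lift the number in this assay clear of that of compound 3, 15.4%, remains open, since the change tested so far leaves the series at modest inhibition of growth. No pair shown isolates the chlorine of the chlorophenyl group on the shared core, so what that atom contributes also stays open.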